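Replacing pyrrolidin-1-yl with 2-(piperazin-1-yl)ethyl on the side chain

The source may hold more compounds than are shown below. What is called first, only, known or untested is meant among the compounds shown, and "the series" means these compounds.

In a functional assay on MCF7 cells (Homo sapiens) for cytotoxicity, read by MTT assay, with a stated time of 72 h (a lower number here means a stronger inhibitor, a higher number a weaker inhibitor), compound 3 `O=C1c2c[n+]([O-])c3ccccc3c2C(=O)c2c1c1ccccc1n2CCN1CCCC1` gives 320 nM, the higher of the two actual numbers in this small set. Compound 2 `CN1CCN(CCCCn2c3c(c4ccccc42)C(=O)c2c[n+]([O-])c4ccccc4c2C3=O)CC1` gives 100 nM, and the gap between them is a 3.2-fold higher number from compound 2 to compound 3 (0.51 log units; beyond the scatter). Compound 1 `O=C1c2c[n+]([O-])c3ccccc3c2C(=O)c2c1c1ccccc1n2Cc1cn(C[C@H](O)CO)nn1` has only a limit, > 1000 nM.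

Compound 4 `O=C1c2c[n+]([O-])c3ccccc3c2C(=O)c2c1c1ccccc1n2CCCCN1CCNCC1` is reached through 2-(piperazin-1-yl)ethyl in place of pyrrolidin-1-yl on a saturated chain carbon, two bonds along the chain from an aromatic nitrogen. The most relevant measurement is a 3.2-fold higher number from compound 2 to compound 3 (0.51 log units; beyond the scatter), a modest step at that same place, where compound 2 carries 2-(4-methylpiperazin-1-yl)ethyl. Read in reverse, it points towards a lower number for compound 4. The steps of an at least 10-fold lower number from compound 1 to compound 2 (1.00 log units; beyond the scatter) and an at least 3.1-fold lower number from compound 1 to compound 3 (0.49 log units; beyond the scatter) start from a limit and concern a different group, so they add little. A modest move to a lower number is expected, estimated as a 2.5-fold lower number from compound 3 to compound 4 (0.39 log units; beyond the scatter), and it may not clear the scatter. For compound 4 the expected value is 130 nM, with an estimated range from 45 nM to 350 nM.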

Compound 4, half-maximal inhibitory concentration: 12000 nM
Compound 4: middle estimate off by 92-fold (1.97 log units), on the low side; the measured number lies above the stated range.
By their numbers in this assay, from the lowest: compound 2; then compound 3; then compound 4.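

In this assay, the methyl on the ring amine nitrogen proves decisive, as hydrogen in its place gives a 120-fold higher number from compound 2 to compound 4 (2.08 log units; beyond the scatter), a large loss from a change that leaves the chain untouched. The earlier compounds had shown only a modest gap at this position, yet 2-(piperazin-1-yl)ethyl in place of pyrrolidin-1-yl gives a 38-fold higher number from compound 3 to compound 4 (1.57 log units; beyond the scatter), so the longer piperazine side chain does not by itself give a stronger compound, and the outcome depends on what sits on its far nitrogen. Compound 1 has only a limit, so the step from it to compound 4 cannot be read: the limit of > 1000 nM in this assay, at which 1 of the 4 values shown sits.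

The compounds shown leave open whether any group on that nitrogen would serve, such as an ethyl or an acetyl in place of the methyl. They also leave open how a pyrrolidine would behave on the longer butyl chain.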